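Aminoquinoline carboxamides: ethylenediamine replacing phenylenediamine

A few compounds are considered here, and "the series" means these few. Any claim that something is new, unique, unknown or untested is made for them only; others in the source may bear on it.

Measured so far:
- compound 2 `Nc1ccc(Nc2c(C(=O)NCc3ccc(F)cc3)nc(Br)c3cccnc23)cc1`: 4000 nM
- compound 3 `N[C@H]1CC[C@H](Nc2c(C(=O)NCc3ccccn3)nc(Br)c3cccnc23)CC1`: 15000 nM
- compound 1 `O=C(NCc1ccc(F)cc1)c1nc(Br)c2cccnc2c1NCCCNc1c(C(=O)NCc2ccc(F)cc2)nc(Br)c2cccnc12`: "not determined" (no result reported)

The series shares one core, varied at the nitrogen on the aromatic ring that carries the amine side arm. In a functional assay on MCF7 cells (Homo sapiens) for cytotoxicity, read by MTT assay, with a stated time of 72 h (on this read-out higher numbers stand for weaker inhibition and lower numbers for stronger inhibition), compound 2 gives 4000 nM, the lowest of the two numbers in hand. Compound 3 gives 15000 nM in this assay, a gap beyond the scatter, so compound 2 stands as the more potent of the pair; compound 1 cannot be placed, as its entry in this assay reads "not determined" (no result reported) and no number was obtained for it.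

Compound 4 `NCCNc1c(C(=O)NCc2ccc(F)cc2)nc(Br)c2cccnc12` is the next entry. It differs from compound 2 in one place: 2-aminoethyl in place of 4-aminophenyl on a nitrogen on an aromatic ring. For the measured compounds named here, no step between measured compounds matches this change. Going by the values given here, the only comparison available is between compound 2 and compound 3, where a non-aromatic amine-bearing arm goes with the higher number.

On that basis the expected step of a 2.0-fold higher number from compound 2 to compound 4 (0.30 log units; within the scatter) in this assay is a moderate rise, beyond the scatter but smaller than the gap to compound 3. Compound 4 is therefore estimated at 8000 nM, with a range from 3000 nM to 25000 nM.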

Compound 4, half-maximal inhibitory concentration: 6000 nM
Compound 4: the middle estimate sits 1.3-fold (0.12 log units) above what was measured; measured number inside the range.
By their numbers in this assay, from the lowest: compounds 2 and 4 (each within the scatter of the next); then compound 3.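

In this assay, putting 2-aminoethyl in place of 4-aminophenyl on a nitrogen on an aromatic ring gives a 1.5-fold higher number from compound 2 to compound 4 (0.18 log units; within the scatter), so the two arms cannot be told apart on this read-out. For the compounds shown here, this is the first comparison that isolates the arm, as the rest of the molecule stays the same, and it shows that for this pair a number in this range does not depend on the arm having a ring: the arm that leaves has 7 heavy atoms and a six-membered aromatic ring of carbon only, while the arm that enters has 3 heavy atoms and no ring. Nothing at hand explains why the two arms read alike.

Open, as far as these compounds go, is how far the arm can be lengthened or altered, for instance whether a 3-aminopropyl chain would stay within the scatter of these two compounds. Also open, from the compounds shown here alone, is what the terminal amine contributes, which a 2-hydroxyethyl arm, with a hydroxyl in place of that amine, or an arm ending in a carboxylic acid would test on the same core.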